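Chain extension toward the phenyl cap in a hydroxamic acid series

The source may hold more compounds than are shown below. What is called first, only, known or untested is meant among the compounds shown, and "the series" means these compounds.

Two compounds were measured in an assay on isolated protein for inhibition of histone deacetylase HD2 (Zea mays); a lower number here means a stronger inhibitor, a higher number a weaker inhibitor. Compound 1 `Cn1cc(C(=O)/C=C/c2ccccc2)cc1/C=C/C=C/C(=O)NO` carries an extended unsaturated linker between its core and the hydroxamic acid and an unsaturated two-carbon bridge to the phenyl ketone; in this assay compound 1 gives 10000 nM. Compound 2 `Cn1cc(C(=O)CCCCCc2ccccc2)cc1/C=C/C(=O)NO` has a shorter vinyl linker to the hydroxamic acid and a saturated five-carbon chain between the carbonyl and the phenyl group; in this assay compound 2 gives 70.8 nM. Of the two numbers, compound 2 stands lowest, and compound 1 sits at a far higher value, a gap that lies well beyond the usual scatter. The two compounds differ in several places at once. For the measured compounds named here, no single step between them can be read.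

Compound 3 `Cn1cc(C(=O)CCCCCCCc2ccccc2)cc1/C=C/C(=O)NO` keeps everything of compound 2 except the change (phenethyl in place of phenyl on a saturated chain carbon, five bonds along the chain from a carbonyl carbon), so the saturated chain grows by two carbons. Going by the values given here, no measured pair isolates such a change in this assay. The step from compound 2 to compound 3 is expected to be modest, a 1.4-fold higher number from compound 2 to compound 3 (0.15 log units; within the scatter), with no confident direction. Compound 3 is estimated at 100 nM, within a range from 30 nM to 320 nM.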

Compound 3, half-maximal inhibitory concentration: 209 nM
Compound 3: middle estimate off by 2.1-fold (0.32 log units), on the low side; the range from low to high includes it.
By their numbers in this assay, from the lowest: compound 2; then compound 3; then compound 1.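

For the compounds shown here, compound 3 provides the first step that can be read at a single place: in this assay, phenethyl in place of phenyl on a saturated chain carbon, five bonds along the chain from a carbonyl carbon, gives a weaker inhibitor (a 3.0-fold higher number from compound 2 to compound 3 (0.47 log units; beyond the scatter)). Lengthening the chain at this position therefore carries a measurable but modest cost, so the saturated chain ending in a phenyl group does not gain from this extension, and the steps from compound 1 to the other two compounds still cannot be read, since it differs from them in several places at once. No measurement shown here offers an explanation for this loss.

As far as these compounds go, with only these two chain lengths compared at this position, it remains open whether a shorter chain or a still longer chain would extend the same direction or whether the numbers would turn. From the compounds shown here alone, it also remains open how an amine or a carboxylic acid in place of the terminal phenyl group would compare with compound 2 in this assay.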